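The compounds below may be only part of what the source reports. "The series", "measured", "known", "first", "only" and "open" are said of these compounds alone.

The compounds share one core, seen in compound 1 `Cc1cccc(NC(=O)CSc2nnc(-c3ccoc3C)n2Cc2ccco2)c1C` and compound 2 `COc1ccccc1NC(=O)CSc1nnc(-c2ccoc2C)n1Cc1ccco1`, and differ only in the group carried on the amide-type nitrogen. In a functional assay on CHO cells for antagonist activity at Orexin receptor type 2 (Homo sapiens), read by FLIPR and calcium flux (a higher number here means a weaker inhibitor, a lower number a stronger inhibitor), compound 1 gives > 15800 nM, which is a limit of the assay and not a number. In this assay compound 2 gives 501 nM. For the measured compounds named here, compound 2 therefore stands as the only number measured here; the other value is a limit. Going by the values given here, the one measured step, an at least 31-fold lower number from compound 1 to compound 2 (1.49 log units; beyond the scatter), shows that this position is sensitive, with the 2-methoxyphenyl group giving a far lower number than the 2,3-dimethylphenyl group, the latter sitting at the limit of > 15800 nM in this assay, at which 1 of the 2 values shown sits.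

Compound 3 `Cc1occc1-c1nnc(SCC(=O)NN2CCc3ccccc32)n1Cc1ccco1` takes the change (2,3-dihydro-1H-indol-1-yl in place of 2-methoxyphenyl on an amide-type nitrogen). Among the compounds with values here, no measured step covers this exchange of an aromatic substituent for a saturated ring nitrogen attached to the amide nitrogen, so the large step from compound 1 to compound 2 only shows that the position matters. A weaker result than compound 2 is expected, with wide uncertainty, as a 5.0-fold higher number from compound 2 to compound 3 (0.70 log units; beyond the scatter). For compound 3 the estimate in this assay is 2500 nM, within 400 nM to 15800 nM.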

Compound 3, inhibition constant: 1000 nM
Estimate against measurement, compound 3: 2.5-fold (0.40 log units) above; the measured number falls inside the stated range.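

The change from 2-methoxyphenyl to 2,3-dihydro-1H-indol-1-yl on the amide-type nitrogen gives, in this assay, a 2.0-fold higher number from compound 2 to compound 3 (0.30 log units; within the scatter), so this position tolerates a group with a five-membered non-aromatic ring and a ring nitrogen, and the result is not tied to the 2-methoxyphenyl group alone. Set against 2,3-dimethylphenyl, the same group gives an at least 15-fold lower number from compound 1 to compound 3 (1.19 log units; beyond the scatter), so two differently built groups now stand apart from 2,3-dimethylphenyl, which is the one group of the three that goes against a low number at this position. Compound 1 remains at a limit of the assay and not a number, so the true size of both steps from it stays unknown: the limit of > 15800 nM in this assay, at which 1 of the 3 values shown sits.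

The compounds shown leave open whether an unsubstituted phenyl, a phenyl carrying an amine or a carboxylic acid, or a longer chain in place of the aromatic group would keep a number of this order. They also leave open whether the tolerance seen here at the amide-type nitrogen holds when the rest of the shared core is changed.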